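The source may report more compounds than this note shows. Statements on the series, on what has been measured and on what is new or still open speak of the compounds shown alone.

Working notes on the series.

In a physicochemical assay for lipophilicity (on this read-out higher numbers stand for higher lipophilicity and lower numbers for lower lipophilicity), compound 1 `CN(C)c1ccc(C(=O)OCC2(CO)C/C(=C\c3cnc4ccccc4c3)C(=O)O2)cc1` gives 3.22, the highest of the three numbers in hand. Compound 2 `CCCC(CCC)C(=O)OCC1(CO)C/C(=C/c2ccncc2)C(=O)O1` gives 2.9 in this assay, and compound 3 `CCCC(CCC)C(=O)OCC1(CO)C/C(=C\c2cccnc2)C(=O)O1` gives 2.9. Among the compounds with values here, both of these stand below compound 1 by a margin beyond the scatter, and compound 2 and compound 3 show the same number as each other; no step between any two of these measured compounds is worked out here, so nothing more is said of those pairs than what their values show.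

Compound 4 `CN(C)c1ccc(C(=O)OCC2(CO)C/C(=C\c3ccc4ccccc4n3)C(=O)O2)cc1` is not yet measured in this assay. Against compound 1 the change is quinolin-2-yl in place of quinolin-3-yl on a double-bonded chain carbon bound to a double-bonded ring carbon. The same atoms are present, joined differently, and the count of rings, donors and acceptors is unchanged. With no measured step of this kind in the series, the expected step in this assay from compound 1 to compound 4 is small, a number 0.08 log units higher from compound 1 to compound 4 (within the scatter), and is expected to stay within the scatter, with no direction that can be justified from the numbers in hand. The expectation for compound 4 in this assay is therefore 3.3, with a range from 2.95 to 3.65.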

Compound 4, partition coefficient: 3.22
The estimate for compound 4 lay 0.08 log units above the measured number; measured number inside the range.
By their numbers in this assay, from the lowest: compounds 2 and 3 (each within the scatter of the next); then compounds 1 and 4 (each within the scatter of the next).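

Quinolin-2-yl in place of quinolin-3-yl on a double-bonded chain carbon bound to a double-bonded ring carbon gives, in this assay, no change at the digits printed from compound 1 to compound 4 (within the scatter), and this is the first step in the series that can be read at all. At this place on the core of compound 1, then, a rearrangement of the same atoms, with the counts of rings, donors and acceptors unchanged, is a change that this read-out does not separate from the starting point. Nothing in hand bears on why the two quinolines read alike.

The compounds shown leave open whether the same flat result would hold for a quinoline carrying a carboxylic acid or a primary amine at this place, or for the same quinoline change with a different ester group on the core. Within the data shown here, compound 2 and compound 3 differ from compound 1 and compound 4 in more than one place, so no steps to them can be read, and the reach of this result beyond this single pair remains unknown.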